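Swapping the Amide Substituent in a Cell Inhibition Series

The source may hold more compounds than are shown below. What is called first, only, known or untested is meant among the compounds shown, and "the series" means these compounds.

Compound 1 `COc1ccc2c(=O)c(/C=C/C(=O)NCc3ccccc3F)coc2c1` gives > 200000 nM in a functional assay on L02 cells (Homo sapiens) for inhibition, read by MTT assay, with a stated time of 48 h (on this read-out lower numbers stand for stronger inhibition and higher numbers for weaker inhibition), which is a limit of the assay and not a number.
Compound 2 `COc1ccc(NC(=O)/C=C/c2coc3cc(O)ccc3c2=O)cc1` gives > 200000 nM in this assay, again a limit rather than a number.
Compound 3 `Cc1ccc(CNC(=O)/C=C/c2coc3cc(O)ccc3c2=O)cc1` gives > 200000 nM in this assay, also a limit rather than a number.

All three measured values sit at the limit of > 200000 nM in this assay, at which 3 of the 3 values shown sit, so compound 1 stands at the limit alongside the other two, and none of the three can be placed above or below another. Going by the values given here, the only step between measured compounds, a step that the two limits leave unreadable from compound 2 to compound 3, is unreadable for the same reason: both ends are limits.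

Compound 4 `CCOc1ccc(NC(=O)/C=C/c2coc3cc(OC)ccc3c2=O)cc1` differs from compound 1 by 4-ethoxyphenyl in place of 2-fluorobenzyl on an amide-type nitrogen. Among the compounds with values here, the one measured step that touches the same place, the group on the amide-type nitrogen, cannot be read, so no measured step gives a direction or a size for this change. What the data do show is that varying the group on the amide nitrogen across three compounds never brought a value below the limit.

Compound 4 is therefore expected to give 250000 nM in this assay, most likely again reported only as a limit. The step this implies is estimated as a step that the limit leaves unreadable from compound 1 to compound 4, nothing beyond the scatter.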

Compound 4, half-maximal inhibitory concentration: > 200000 nM
Compound 4: a limit, no number (the forecaster's own chance of this, stated with the estimate: 85%); the middle value does not contradict the limit.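

No new step can be read: compound 1 and compound 4 are both limits and not numbers, so the size of the change between them stays unknown, and all four compounds sit together: the limit of > 200000 nM in this assay, at which 4 of the 4 values shown sit.

The compounds shown leave open whether any compound of this kind gives an actual number in this assay, and so how far the group on the amide-type nitrogen matters there.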